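The compounds below may be only part of what the source reports. "The series", "measured", "known", "first", "only" and "open" are said of these compounds alone.

Compound 2 `CCOC(=O)C1=Cc2ccccc2OC1(OCc1cn(CC(=O)Nc2ccc(C)cc2)nn1)C(F)(F)F` gives 67400 nM in a functional assay on HeLa cells (Homo sapiens) for inhibition, read by MTT assay, with a stated time of 24 h (a lower number here means a stronger inhibitor, a higher number a weaker inhibitor), the higher of the two numbers available, though compound 3 `Cc1ccc(-c2cc(COC3(C(F)(F)F)Oc4ccccc4C=C3C(=O)O)on2)cc1` at 33400 nM lies within the scatter of it. Compound 1 `CCOC(=O)C1=Cc2ccccc2OC1(OCc1cc(-c2ccc(C)cc2)no1)C(F)(F)F` sits at the assay limit, > 150000 nM, and that is all its measurement tells. Within the data shown here, the only measured step, an at least 4.4-fold lower number from compound 1 to compound 3 (0.65 log units; beyond the scatter), concerns the ester group and says nothing about the substituent on the aromatic nitrogen. Compound 4 `CCOC(=O)C1=Cc2ccccc2OC1(OCc1cn(-c2ccc([N+](=O)[O-])cc2)nn1)C(F)(F)F` differs from compound 2 by 4-nitrophenyl in place of ((4-methylphenyl)carbamoyl)methyl on an aromatic nitrogen. No measured step bears on this exchange, so nothing shown points to either direction, and a result within the scatter is expected in this assay. Compound 4 is estimated at 60000 nM, between 20000 nM and 180000 nM. The expected step is a 1.1-fold lower number from compound 2 to compound 4 (0.05 log units; within the scatter).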

Compound 4, half-maximal inhibitory concentration: > 150000 nM
Compound 4: no number, only a limit (the forecaster's own chance of this, stated with the estimate: 30%); middle value at least 2.5-fold (0.39 log units) away from the limit.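

In this assay, the substituent on the aromatic nitrogen is not neutral: 4-nitrophenyl in place of ((4-methylphenyl)carbamoyl)methyl brings an at least 2.2-fold higher number from compound 2 to compound 4 (0.34 log units; beyond the scatter). For compound 4, > 150000 nM is a limit of the assay and not a number. The step therefore has a floor but no known size, and the reading stops at the same limit as compound 1: the limit of > 150000 nM in this assay, at which 2 of the 4 values shown sit.

On these data alone, the exchange replaces a whole group, so which part of it matters stays open. Also open, as far as these compounds go, is how an aminophenyl group would read on this nitrogen, and whether a carboxylic acid in place of the ethyl ester would shift compound 2 or compound 4.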